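Series notes: compound 3 to compound 4

A few compounds are considered here, and "the series" means these few. Any claim that something is new, unique, unknown or untested is made for them only; others in the source may bear on it.

Measured so far:
compound 1 `CC(C)n1cnc2c(Nc3ccccc3)nc(NCOCc3ccc(C(=O)Nc4ccccc4N)cc3)nc21`: 50.2%
compound 2 `Nc1ccccc1NC(=O)c1ccc(COCNc2nc(Nc3ccccc3)c3ncn(C4CCCC4)c3n2)cc1`: 66.9%
compound 3 `CCCCn1cnc2c(Nc3ccccc3)nc(NCOCc3ccc(/C=C/C(=O)Nc4ccccc4N)cc3)nc21`: 59.3%

In a functional assay on HepG2 cells (Homo sapiens) for antiproliferative activity, read by CCK-8 assay, with a stated time of 72 h, tested at 8 uM (a lower number here means a weaker effect, a higher number a stronger effect of the compound at the concentration tested), compound 3 stands second highest of the three numbers. Its nearest neighbour is compound 2, whose number is higher by an amount within the scatter, and its furthest is compound 1, whose number is lower, again within the scatter; so compound 3 cannot be ordered against either on these data.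

Compound 4 `CCCCn1cnc2c(Nc3ccccc3)nc(NCOCc3ccc(C(=O)Nc4ccccc4N)cc3)nc21` differs from compound 3 in one place: (2-aminophenyl)carbamoyl in place of 2-((2-aminophenyl)carbamoyl)ethenyl on an aromatic carbon

Going by the values given here, no measured step covers this exchange of 2-((2-aminophenyl)carbamoyl)ethenyl for (2-aminophenyl)carbamoyl. Among the compounds with values here, the only measured step, a number 16.7 percentage points higher from compound 1 to compound 2 (beyond the scatter), concerns the group on the aromatic nitrogen and not the carbamoyl end; it is of modest size and gives no direction for the present change. Compound 1 and compound 2 both carry the (2-aminophenyl)carbamoyl group that enters here. Compound 1 gives 50.2% and compound 2 gives 66.9%, and these two values bracket the value of compound 3. Compound 4 is therefore expected to fall near compound 3, with a step of a number 1.3 percentage points lower from compound 3 to compound 4 (within the scatter) that is not expected to exceed the scatter. The estimate for compound 4 in this assay is 58%, within a range from 44% to 72%.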

Compound 4, a percentage reported as inhibition, at one concentration (the size of the read-out at that concentration, not a potency): 70.7%
Compound 4: the middle estimate sits 12.7 percentage points below what was measured, within the range that was stated.
By their numbers in this assay, from the lowest: compounds 1, 3, 2 and 4 (each within the scatter of the next, the first and the last beyond it).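

In this assay, the exchange on the aromatic carbon para to a large group, with (2-aminophenyl)carbamoyl in place of 2-((2-aminophenyl)carbamoyl)ethenyl, gives a number 11.4 percentage points higher from compound 3 to compound 4 (beyond the scatter), the first reading showing that this position responds to a change at the carbamoyl end, at least with butyl on the aromatic nitrogen. With (2-aminophenyl)carbamoyl held constant, butyl in place of isopropyl gives a number 20.5 percentage points higher from compound 1 to compound 4 (beyond the scatter), whereas butyl in place of cyclopentyl gives a number 3.8 percentage points higher from compound 2 to compound 4 (within the scatter), so butyl and cyclopentyl cannot be ordered here, though each stands apart from isopropyl. Nothing available accounts for either of the steps beyond the scatter.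

Going by these compounds alone, the exchange at the carbamoyl end has been read with butyl alone, so its outcome with isopropyl or cyclopentyl on the aromatic nitrogen remains open, and these single-concentration percentages give no potency for any compound. Also open, going by these compounds, are a hydroxamic acid in place of the (2-aminophenyl)carbamoyl group and a longer chain, such as hexyl, on the aromatic nitrogen.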